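Piperazine aryl swap in the aminothiophene ketone series

The source may hold more compounds than are shown below. What is called first, only, known or untested is meant among the compounds shown, and "the series" means these compounds.

Measured in a functional assay on CHO cells with adenosine receptor A1 (Homo sapiens) as the target, read by cAMP accumulation and immunoassay, with a stated time of 6 min, tested at 0.01 uM; on this read-out lower numbers stand for a stronger effect and higher numbers for a weaker effect at the one concentration tested:
compound 1 `CC(C)N1CCN(Cc2csc(N)c2C(=O)c2ccc(Cl)cc2)CC1` — -1%
compound 2 `Nc1scc(CN2CCN(c3ccc(Cl)cc3F)CC2)c1C(=O)c1ccc(Cl)cc1` — -9.2%
compound 3 `Nc1scc(CN2CCN(c3cccc4ccccc34)CC2)c1C(=O)c1ccc(Cl)cc1` — 8.7%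

Compound 2 holds the lowest of the three numbers; its gap to compound 1 is within the scatter, so no order between them is claimed, while its gap to compound 3 is beyond it (a number 17.9 percentage points higher from compound 2 to compound 3 (beyond the scatter)). Compound 4 `Nc1scc(CN2CCN(c3cc(F)ccc3F)CC2)c1C(=O)c1ccc(Cl)cc1` differs from compound 2 in one place: 2,5-difluorophenyl in place of 4-chloro-2-fluorophenyl on an amine nitrogen in a ring. The step from compound 1 to compound 2 (a number 8.2 percentage points lower from compound 1 to compound 2 (within the scatter)) shows that exchanging the group on the ring nitrogen for a phenyl moved nothing beyond scatter; only the naphthalen-1-yl step was modest. A phenyl-for-phenyl exchange is therefore expected to give no step beyond the scatter, a number 5.2 percentage points higher from compound 2 to compound 4 (within the scatter). Compound 4 is estimated at -4%, within -18% to 10%.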

Compound 4, a percentage reported as activity, at one concentration (the size of the read-out at that concentration, not a potency): 3.1%
The estimate for compound 4 lay 7.1 percentage points below the measured number; the measured number falls inside the stated range.
By their numbers in this assay, from the lowest: compounds 2, 1, 4 and 3 (each within the scatter of the next, the first and the last beyond it).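

Exchanging one substituted phenyl for another on this amine nitrogen is not neutral in this assay: a number 12.3 percentage points higher from compound 2 to compound 4 (beyond the scatter), so 2,5-difluorophenyl and 4-chloro-2-fluorophenyl are not interchangeable at this position. Against isopropyl and naphthalen-1-yl, 2,5-difluorophenyl establishes no order: a number 4.1 percentage points higher from compound 1 to compound 4 (within the scatter) and a number 5.6 percentage points lower from compound 3 to compound 4 (within the scatter). The data offer no explanation for the step from 4-chloro-2-fluorophenyl.

Still open, as far as these compounds go, is whether a benzyl group or a phenyl carrying a carboxylic acid on this nitrogen would give a number outside the narrow span seen so far.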